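The source may hold more compounds than are shown below. What is called first, only, known or untested is meant among the compounds shown, and "the series" means these compounds.

Measured so far in an assay on cells for inhibition of HSP60/HSP10 (Homo sapiens), with a stated time of 60 min; on this read-out higher numbers stand for weaker inhibition and lower numbers for stronger inhibition:
compound 1 `O=S(=O)(Nc1ccc(-c2nc3ccccc3o2)cc1)c1cccs1` gives 63000 nM
compound 2 `O=S(=O)(Nc1ccc(-c2nc3ccccc3o2)cc1)c1ccc(F)cc1` gives 73000 nM

Going by the values given here, compound 2 stands at the higher of the two numbers in this assay, but its only neighbour is compound 1, and the step of a 1.2-fold higher number from compound 1 to compound 2 (0.06 log units; within the scatter) is within the scatter, so the two compounds cannot be ordered on these data. Compound 3 `COc1cccc(S(=O)(=O)Nc2ccc(-c3nc4ccccc4o3)cc2)c1` is not yet measured. It differs from compound 2 in one place: 3-methoxyphenyl in place of 4-fluorophenyl on a sulfonyl sulfur. Among the compounds with values here, the only measured step, from compound 1 to compound 2, is also an exchange of the group on the sulfonyl sulfur, and it produced no change beyond the scatter in this assay; no measured step involves a methoxy group, so nothing directly tests the entering 3-methoxyphenyl. Within the data shown here, on the single step available, the change from compound 2 to compound 3 is expected to stay within the scatter, with no direction favoured, which gives an estimated step of a 1.0-fold lower number from compound 2 to compound 3 (0.02 log units; within the scatter). Compound 3 is therefore expected to give about 70000 nM in this assay, with a range from 30000 nM to 160000 nM.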

Compound 3, half-maximal inhibitory concentration: 80000 nM
Estimate against measurement, compound 3: 1.1-fold (0.06 log units) below; low and high end bracket the measured number.
By their numbers in this assay, from the lowest: compounds 1, 2 and 3 (each within the scatter of the next).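

Across the three groups now seen on the sulfonyl sulfur, the reading in this assay does not separate 3-methoxyphenyl from either neighbour: the exchange for 4-fluorophenyl gives a 1.1-fold higher number from compound 2 to compound 3 (0.04 log units; within the scatter) and the exchange for thiophen-2-yl gives a 1.3-fold higher number from compound 1 to compound 3 (0.10 log units; within the scatter) as the comparison across the series. The earlier pair tested only thiophen-2-yl against 4-fluorophenyl, whereas this result adds a larger group by heavy-atom count, one carrying the hydrogen-bond acceptor and the oxygen that 4-fluorophenyl lacks, and neither difference gives a step beyond the scatter, so compounds 1, 2 and 3 cannot be ordered. No available evidence accounts for this lack of separation.

Going by these compounds, all three compounds keep the shared core and an aromatic ring on the sulfonyl sulfur, so it remains open whether a ring carrying an amine or a carboxylic acid, or a plain alkyl chain in place of the ring, would give a step beyond the scatter. On these data alone, how far the sulfonamide nitrogen or the shared core itself governs the reading also remains open on these compounds.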